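From compound 2 to compound 4: an untested exchange

A few compounds are considered here, and "the series" means these few. Any claim that something is new, unique, unknown or untested is made for them only; others in the source may bear on it.

- compound 1 (`COc1ccc(C(=O)CCN2CCN(c3ccc(F)cc3)CC2)cc1OC`) gives 175000 nM in this series
- compound 2 (`COc1ccc(C(=O)CCN2CCN(c3ccc(C(F)(F)F)cc3)CC2)cc1OC`) gives 243000 nM in this series
- compound 3 (`COc1ccc(C(=O)CCN2CCN(c3ccc(Cl)cc3)CC2)cc1OC`) gives 185000 nM in this series

All three values come from an ADME assay on Vero cells (Chlorocebus sabaeus) for cytotoxicity, read by resazurin assay, with a stated time of 72 h (a higher number here means a weaker inhibitor, a lower number a stronger inhibitor), and lie within the scatter of one another, so compound 2 stands level with compound 1 and compound 3. Compound 4 (`O=C(CCN1CCN(c2ccc(C(F)(F)F)cc2)CC1)c1ccc(Cl)c(F)c1`) carries 4-chloro-3-fluorophenyl in place of 3,4-dimethoxyphenyl on a carbonyl carbon, and it has not yet been measured.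

The measured steps bear on this only indirectly. They are a 1.4-fold higher number from compound 1 to compound 2 (0.14 log units; within the scatter) and a 1.1-fold higher number from compound 1 to compound 3 (0.02 log units; within the scatter) and a 1.3-fold lower number from compound 2 to compound 3 (0.12 log units; within the scatter) and each exchanges fluoro, chloro or trifluoromethyl on an aromatic carbon. For the measured compounds named here, all three stay within the scatter, yet none touches the group on the carbonyl carbon, and the data hold no measured step at that place. No step beyond the scatter is therefore expected in this assay, with a slight, loosely held lean towards a lower number. The expected step is small (a 1.9-fold lower number from compound 2 to compound 4 (0.27 log units; within the scatter)) on this estimate. For compound 4 an estimated 130000 nM is expected, with a wide range from 50000 nM to 300000 nM in this estimate.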

Compound 4, half-maximal inhibitory concentration: 74300 nM
Beside the measured number, compound 4's estimate is 1.7-fold (0.24 log units) above it, within the range that was stated.
By their numbers in this assay, from the lowest: compound 4; then compounds 1, 3 and 2 (each within the scatter of the next).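

In this assay, the group on the carbonyl carbon turns out to be a place where the number can move beyond the scatter (a 3.3-fold lower number from compound 2 to compound 4 (0.51 log units; beyond the scatter)), with 4-chloro-3-fluorophenyl in place of 3,4-dimethoxyphenyl. The earlier exchanges of fluoro, chloro and trifluoromethyl on an aromatic carbon all stayed within the scatter, so this modest step is the only one shown that leaves it. Nothing measured here accounts for the step.

The exchange alters the whole aryl group at once, so the compounds shown do not separate the part played by the chloro, the fluoro or the two methoxy groups. Also open, as far as these compounds go, is how a single methoxy group, an unsubstituted phenyl or a pyridine ring would read on the same carbonyl carbon.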